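A few compounds are considered here, and "the series" means these few. Any claim that something is new, unique, unknown or untested is made for them only; others in the source may bear on it.

Measured compounds in a physicochemical assay for lipophilicity, read by HPLC, measured as chromatographic lipophilicity, at pH 7.4; a higher number here means a more lipophilic compound, a lower number a more polar compound:

compound 1, `CC(C)(C)C(=O)N1N=CCC1c1c[nH]cn1`: 1.7
compound 2, `CC(C)(C)C(=O)N1N=CCC1C1CCCCC1`: 7.3
compound 3, `O=C(c1ccccn1)N1CCC(C(=O)N2N=CCC2c2ccccc2)CC1`: 3.1

Compound 1 stands lowest of the three in this assay. Its nearest neighbour is compound 3, which lies above it by a gap beyond the usual scatter, and its furthest is compound 2, which lies far above it, again well beyond the scatter. For the measured compounds named here, no single-point step between two measured compounds is available here, so the comparison rests on the values themselves.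

The unmeasured compound 4, `CC(C)(C)C(=O)N1N=CCC1C1CCCC1`, differs from compound 1 in one place: cyclopentyl in place of 1H-imidazol-4-yl on a saturated ring carbon. The group that leaves carries a hydrogen-bond donor and an acceptor; the group that enters carries none.

Because compound 2 gives 7.3 in this assay, a large upward step is expected from this change. The step of a number 4.70 log units higher from compound 1 to compound 4 (beyond the scatter) is estimated to be far beyond the scatter. Compound 4 is expected to give about 6.4, within a range from 5.4 to 7.3.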

Compound 4, distribution coefficient: 6.7
Estimate against measurement, compound 4: 0.30 log units below, and the stated range covers the measured number.
By their numbers in this assay, from the lowest: compound 1; then compound 3; then compound 4; then compound 2.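

In this assay, for the compounds shown here, this saturated ring carbon now has a single-place change that can be read directly (a number 5.00 log units higher from compound 1 to compound 4 (beyond the scatter)), which the earlier compounds did not offer. The step is large even though the heavy-atom count stays the same: 1H-imidazol-4-yl, with its hydrogen-bond donor and acceptor, gives way to cyclopentyl, a ring of carbon only with neither. Nothing measured here explains the size of this step.

The two compounds do not separate the loss of the hydrogen-bond donor and acceptor from the loss of the aromatic ring, since all of these change together. Where this assay would place a 1-methylimidazolyl group at this carbon, or an amine carried on the cyclopentyl ring, remains open.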